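The source may report more compounds than this note shows. Statements on the series, on what has been measured and on what is new or still open speak of the compounds shown alone.

Three compounds sharing one core were tested in a functional assay on MCF7 cells (Homo sapiens) for antiproliferative activity, read by MTT assay, with a stated time of 48 h; a lower number here means a stronger inhibitor, a higher number a weaker inhibitor. Compound 1 `N#CC1=C(N)Oc2c(c3nc4ccccc4nc3c3ccccc23)C12C(=O)N(Cc1cnnn1-c1cccc(Cl)c1)c1ccccc12` gives 43600 nM. Compound 2 `N#CC1=C(N)Oc2c(c3nc4ccccc4nc3c3ccccc23)C12C(=O)N(Cc1cnnn1-c1cccc(Br)c1)c1ccccc12` gives only a limit of the assay, > 50000 nM. Compound 3 `COc1ccc(-n2nncc2CN2C(=O)C3(C(C#N)=C(N)Oc4c3c3nc5ccccc5nc3c3ccccc43)c3ccccc32)cc1` likewise reaches only a limit, > 50000 nM. Among the measured compounds shown here, compound 3 therefore stands at the limit of > 50000 nM in this assay, at which 2 of the 3 values shown sit; the measured step of an at least 1.1-fold higher number from compound 1 to compound 3 (0.05 log units; that floor lies within the scatter) says only that its number is not lower than that of compound 1, and the step that the two limits leave unreadable from compound 2 to compound 3 cannot be read. Compound 4 `CC(=O)Nc1ccc(-n2nncc2CN2C(=O)C3(C(C#N)=C(N)Oc4c3c3nc5ccccc5nc3c3ccccc43)c3ccccc32)cc1` differs from compound 3 by acetamido in place of methoxy on an aromatic carbon. For the measured compounds named here, no measured step covers this particular change. Compound 4 is expected to stay near the limit, with a number no higher from compound 3 to compound 4 (the limit leaves the size open) meaning no movement beyond the scatter. Compound 4 is estimated at 50000 nM, between 20000 nM and 120000 nM.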

Compound 4, half-maximal inhibitory concentration: > 50000 nM
Compound 4: only a limit was reported; the forecaster's own chance of this, stated with the estimate: 70%; the middle value lies on the limit itself.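

Acetamido, para to a large group, brings a hydrogen-bond donor that methoxy lacks, yet in this assay compound 4 still gives only a limit, so this change adds a further compound to those without a measured number: the limit of > 50000 nM in this assay, at which 3 of the 4 values shown sit. The steps from compound 3 to compound 4 and from compound 2 to compound 4 cannot be read, as both ends of each are limits. Among the compounds shown here, the one readable step is an at least 1.1-fold higher number from compound 1 to compound 4 (0.05 log units; that floor lies within the scatter), so nothing places compound 4 lower than compound 1.

As far as these compounds go, how far compound 2, compound 3 and compound 4 lie past the limit stays open. Also open, from the compounds shown here alone, is whether an amine or a carboxylic acid at this place on the ring would give a measurable number.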